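Swapping the Aryl Group on a Sulfonyl Sulfur

The source may hold more compounds than are shown below. What is called first, only, known or untested is meant among the compounds shown, and "the series" means these compounds.

Measured compounds:
compound 1 `COc1cc2nc(N3CCN(S(=O)(=O)c4ccc(I)cc4)CC3)nc(N)c2cc1OC`: 15000 nM
compound 2 `COc1cc2nc(N3CCN(S(=O)(=O)c4ccccc4[N+](=O)[O-])CC3)nc(N)c2cc1OC`: 35000 nM
compound 3 `COc1cc2nc(N3CCN(S(=O)(=O)c4cccc([N+](=O)[O-])c4)CC3)nc(N)c2cc1OC`: 32000 nM

The three measured compounds share one core and differ only in the aryl group on a sulfonyl sulfur. In a functional assay on PC-3 cells (Homo sapiens) for inhibition (a higher number here means a weaker inhibitor, a lower number a stronger inhibitor), compound 1 gives 15000 nM, the lowest of the three numbers. Moving from the 4-iodophenyl of compound 1 to a nitrophenyl raised the number in both cases: a 2.3-fold higher number from compound 1 to compound 2 (0.37 log units; beyond the scatter) and a 2.1-fold higher number from compound 1 to compound 3 (0.33 log units; beyond the scatter). Between the two nitrophenyl compounds there is a 1.1-fold lower number from compound 2 to compound 3 (0.04 log units; within the scatter).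

Compound 4 `COc1cc2nc(N3CCN(S(=O)(=O)c4cc(Cl)ccc4Cl)CC3)nc(N)c2cc1OC` has not yet been measured. It differs from compound 1 as follows: 2,5-dichlorophenyl in place of 4-iodophenyl on a sulfonyl sulfur. For the measured compounds named here, no measured step covers this exact change, so the only guide is that both replacements of the same 4-iodophenyl seen so far gave modest increases. A small step upward, or none beyond the scatter, is therefore expected in this assay, as a 1.5-fold higher number from compound 1 to compound 4 (0.17 log units; within the scatter). Compound 4 is estimated at 22000 nM, with a likely range from 9000 nM to 55000 nM.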

Compound 4, half-maximal inhibitory concentration: 60000 nM
For compound 4 the middle estimate is 2.7-fold (0.44 log units) below the measured one; the measured number lies above the stated range.
By their numbers in this assay, from the lowest: compound 1; then compounds 3, 2 and 4 (each within the scatter of the next).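

Compound 1 now stands apart from three different replacements of its 4-iodophenyl, since the 2,5-dichlorophenyl of compound 4 also gives a higher number in this assay, with a 4.0-fold higher number from compound 1 to compound 4 (0.60 log units; beyond the scatter). This makes compound 1 the strongest inhibitor of the four. The new group cannot be separated from either nitrophenyl group, as a 1.9-fold higher number from compound 3 to compound 4 (0.27 log units; within the scatter) and a 1.7-fold higher number from compound 2 to compound 4 (0.23 log units; within the scatter) both lie within the scatter, so two chlorine atoms and a single nitro group give results that these data do not distinguish.

Nothing measured here bears on why the 4-iodophenyl stands apart from the other aryl groups. On these data alone, it remains open whether the iodine itself matters, and how a plain phenyl, a methyl group or an aryl group carrying an amine would compare on the same sulfonyl sulfur.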